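The source may hold more compounds than are shown below. What is called first, only, known or untested is meant among the compounds shown, and "the series" means these compounds.

Measured so far:
- compound 1, `O=S(=O)(/C=C/c1ccc(Cl)cn1)c1cccc(F)c1`: 2500 nM
- compound 2, `O=S(=O)(/C=C/c1ccccn1)c1cccc(Cl)c1`: 1430 nM
- compound 3, `O=S(=O)(/C=C/c1ncccc1Cl)c1cccc(Cl)c1`: 46 nM

These three compounds were tested in an assay on U2OS cells for activation of nuclear factor erythroid 2-related factor 2 (Homo sapiens), read by beta-arrestin recruitment, with a stated time of 6 h; a higher number here means that more compound is needed for the effect, a lower number that less compound is needed. Compound 2 stands second highest of the three numbers; its nearest neighbour is compound 1, whose value lies within the usual scatter of it, while compound 3 is far lower and that gap is beyond the scatter.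

The unmeasured compound is compound 4, `O=S(=O)(/C=C/c1ccc(Cl)cn1)c1cccc(Cl)c1`. It differs from compound 2 in one place: chloro in place of hydrogen on an aromatic carbon

Among the compounds with values here, the only measured one-place step is a 31-fold lower number from compound 2 to compound 3 (1.49 log units; beyond the scatter), which also adds a chloro to the same ring, but at a different carbon. The compound that carries a chloro at the same place as compound 4 is compound 1, and its value is close to that of compound 2, although compound 1 also differs from compound 2 on the other ring. The step to compound 4 is therefore expected to be small, a 1.2-fold lower number from compound 2 to compound 4 (0.08 log units; within the scatter), with the large step seen in compound 3 not carried over. For compound 4 the estimate in this assay is 1200 nM, with a range from 350 nM to 4000 nM.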

Compound 4, half-maximal effective concentration: 1510 nM
The estimate for compound 4 lay 1.3-fold (0.10 log units) below the measured number, and the stated range covers the measured number.
By their numbers in this assay, from the lowest: compound 3; then compounds 2, 4 and 1 (each within the scatter of the next).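

In this assay, a chloro on the ring carbon two atoms from the ring nitrogen, para to a large group, makes no change beyond the scatter: the step is a 1.1-fold higher number from compound 2 to compound 4 (0.02 log units; within the scatter) and stays small, whereas a chloro on a different carbon of the same ring gave a 31-fold lower number from compound 2 to compound 3 (1.49 log units; beyond the scatter), so on this ring the outcome depends on which carbon carries the chloro. On the other ring, chloro in place of fluoro gives a 1.7-fold lower number from compound 1 to compound 4 (0.22 log units; within the scatter), which is also within the scatter, so this single change can now be read apart from the difference on the first ring. Nothing given here explains why the two carbons of the ring behave so differently.

On these data alone, whether a methoxy group or an amine on the same carbon would also leave the number within the scatter remains open. So does the result of carrying both ring chloro groups, those of compound 3 and compound 4, in one compound.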